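A few compounds are considered here, and "the series" means these few. Any claim that something is new, unique, unknown or untested is made for them only; others in the source may bear on it.

Working notes on the series. Among the measured compounds shown here, compound 3 `Cc1cccc(-c2noc(C3CN(C(=O)c4ccccc4F)C3)n2)c1` gives 1400 nM in an assay on HEK293 cells for negative allosteric modulation of metabotropic glutamate receptor 5 (Homo sapiens), read by FLIPR (a lower number here means a stronger inhibitor, a higher number a weaker inhibitor), and is the only compound of the three measured that returns a number rather than a limit. Compound 1 `CC1CCC(C(=O)N2CC(c3nc(-c4cccc(Cl)c4)no3)C2)CC1` gives > 10000 nM in this assay, which is a limit. Compound 2 `O=C(N1CCCCCC1)N1CC(c2nc(-c3cccc(Cl)c3)no2)C1` likewise gives > 10000 nM in this assay, again a limit. The step that the two limits leave unreadable from compound 1 to compound 2 is therefore not readable, as both ends sit at the limit of > 10000 nM in this assay, at which 2 of the 3 values shown sit.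

Compound 4 `O=C(c1ccccc1F)N1CC(c2nc(-c3cccc(Cl)c3)no2)C1` differs from compound 3 by chloro in place of methyl on an aromatic carbon. For the measured compounds named here, no measured step touches this part of the molecule: the only step recorded, from compound 1 to compound 2, changes the group on the carbonyl carbon and leaves the aryl ring untouched, and it is unreadable anyway. Compounds 1 and 2 carry the same 3-chlorophenyl as compound 4, but their limits give no number to set against compound 3. Going by the values given here, with no bearing step, the expected step of no change at the digits printed from compound 3 to compound 4 (within the scatter) is none beyond the scatter. Compound 4 is estimated at 1400 nM in this assay, within 450 nM to 4500 nM.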

Compound 4, half-maximal inhibitory concentration: 670 nM
Beside the measured number, compound 4's estimate is 2.1-fold (0.32 log units) above it; the measured number falls inside the stated range.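

In this assay, among the compounds shown here, chloro in place of methyl on the aromatic carbon gives a 2.1-fold lower number from compound 3 to compound 4 (0.32 log units; beyond the scatter), so this position now has a readable step where the earlier compounds offered none. On the carbonyl carbon, 2-fluorophenyl in place of azepan-1-yl gives an at least 14-fold lower number from compound 2 to compound 4 (1.17 log units; beyond the scatter), and 2-fluorophenyl in place of 4-methylcyclohexyl gives an at least 14-fold lower number from compound 1 to compound 4 (1.17 log units; beyond the scatter), which ties the weak end of the series to these two non-aromatic groups for the compounds shown. Both of these steps start from a limit and not from a number: the limit of > 10000 nM in this assay, at which 2 of the 4 values shown sit.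

The step between the two compounds at that limit cannot be read. Still open, as far as these compounds go, is how methoxy or an amine at the same aromatic carbon would compare with chloro and methyl, and whether a phenyl without fluorine on the carbonyl carbon would hold the value of compound 4.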